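Cytotoxicity limits and a methylated benzylamine variant

The compounds below may be only part of what the source reports. "The series", "measured", "known", "first", "only" and "open" are said of these compounds alone.

Compound 1 `O=c1cc(NCc2cccc(F)c2)sc2c([N+](=O)[O-])cc(C(F)(F)F)cc12`: in an ADME assay on Vero cells (Chlorocebus sabaeus) for cytotoxicity, read by MTT assay, with a stated time of 48 h (a lower number here means a stronger inhibitor, a higher number a weaker inhibitor), compound 1 reaches only the limit > 64 ug/mL.
Compound 2 `COc1ccc(CNc2cc(=O)c3cc(C(F)(F)F)cc([N+](=O)[O-])c3s2)cc1OC`: in this assay compound 2 likewise reaches only the limit > 64 ug/mL.

Among the compounds with values here, both values are limits of the assay and not numbers, so compound 1 stands at the limit without a number of its own, and the one further value shown, for compound 2, is also a limit (the limit of > 64 ug/mL in this assay, at which 2 of the 2 values shown sit). The step that the two limits leave unreadable from compound 1 to compound 2 is therefore of unreadable size. Compound 3 `CN(Cc1ccccc1)c1cc(=O)c2cc(C(F)(F)F)cc([N+](=O)[O-])c2s1` is unmeasured; it differs from compound 1 by benzyl(methyl)amino in place of (3-fluorobenzyl)amino on an aromatic carbon. Within the data shown here, the only measured step exchanges the ring-bound group on the saturated chain carbon rather than the amine itself, and its size cannot be read; no measured step mirrors the change to compound 3. Against two limits, no shift in either direction beyond the scatter can be argued for. Compound 3 is therefore expected to give about 80 ug/mL, within 32 ug/mL to 200 ug/mL, in this assay, which would mean an expected step that the limit leaves unreadable from compound 1 to compound 3, most probably again reported only as a limit.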

Compound 3, half-maximal inhibitory concentration: > 64 ug/mL
Compound 3: a limit, no number; the forecaster's own chance of this, stated with the estimate: 75%; the middle value is on the limit's open side.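

In this assay compound 3 reaches only > 64 ug/mL, a limit and not a number. No new step can be read between compound 1 and compound 3, since the values shown all stand at one limit: the limit of > 64 ug/mL in this assay, at which 3 of the 3 values shown sit.

The compounds shown leave open where the cytotoxicity of each actually lies and whether the changes between them alter it.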